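The compounds below may be only part of what the source reports. "The series", "measured", "known", "first", "only" and "open" are said of these compounds alone.

In an ADME assay on MT4 cells (Homo sapiens) for cytotoxicity, read by MTT assay, with a stated time of 4 days (on this read-out lower numbers stand for higher toxicity in this test and higher numbers for lower toxicity in this test), three compounds built on one shared core have been measured. Compound 1, with the structure `O=c1cc(Cc2c(F)cccc2F)nc(N2CCCC2)[nH]1`, carries a pyrrolidin-1-yl group. In this assay compound 1 gives only a limit, > 86000 nM. Compound 2, `O=c1cc(Cc2c(F)cccc2F)nc(N2CCCCC2)[nH]1`, differs from compound 1 in one place: piperidin-1-yl in place of pyrrolidin-1-yl on an aromatic carbon. For compound 2 this assay reports a limit, > 82000 nM. Compound 3, `Cc1c(Cc2c(F)cccc2F)nc(N2CCCC2)[nH]c1=O`, differs from compound 1 in another place: methyl in place of hydrogen on an aromatic carbon. Compound 3 reaches only a limit in this assay, > 82000 nM. Because the values sit at the limit of > 82000 nM in this assay, at which 2 of the 3 values shown sit, and at the limit of > 86000 nM in this assay, at which 1 of the 3 values shown sits, the step that the two limits leave unreadable from compound 1 to compound 2 cannot be read, and the same holds for a step that the two limits leave unreadable from compound 1 to compound 3. Compound 4, `Cc1c(Cc2c(F)cccc2F)nc(N2CCCCC2)[nH]c1=O`, is not yet measured; it differs from compound 3 as follows: piperidin-1-yl in place of pyrrolidin-1-yl on an aromatic carbon. This is the same kind of change as from compound 1 to compound 2, but here the place is also para to a methyl group (1 heavy atom). The measured step that the two limits leave unreadable from compound 1 to compound 2 is unreadable, so the expected step is a step that the limit leaves unreadable from compound 3 to compound 4. For compound 4 the value in this assay is estimated at 85000 nM, with a limit the likely outcome.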

Compound 4, half-maximal cytotoxic concentration: > 78000 nM
Compound 4 was reported as a limit; the forecaster's own chance of this, stated with the estimate: 90%; the middle value does not contradict the limit.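

In this assay compound 4 reaches only a limit, just as compound 2 and compound 3 do, so neither of its steps, from compound 3 or from compound 2, can be read: the limit of > 78000 nM in this assay, at which 1 of the 4 values shown sits.

The compounds shown leave open what concentration, if any, is toxic to these cells, and whether swapping pyrrolidin-1-yl for piperidin-1-yl or adding methyl changes it.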